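Removing the Chlorine From a Chalcone Growth Inhibitor

The compounds below may be only part of what the source reports. "The series", "measured", "known", "first", "only" and "open" are said of these compounds alone.

Compound 1 `COc1cc(/C=C/C(=O)c2cccc(-n3cc(-c4ccc(Cl)cc4)[nH]c3=O)c2)cc(OC)c1OC` was tested in a functional assay on TK-10 cells (Homo sapiens) for inhibition (on this read-out lower numbers stand for stronger inhibition of growth and higher numbers for weaker inhibition of growth), and gave 6460 nM. For the measured compounds named here, compound 2 `COc1cc(/C=C/C(=O)c2cccc(-n3cc(-c4ccccc4)[nH]c3=O)c2)ccc1O`, which differs from it in several places, gave 5290 nM in this assay; the two numbers lie within the scatter of each other, so compound 1 stands level with the only other measured compound. Compound 3 `COc1cc(/C=C/C(=O)c2cccc(-n3cc(-c4ccccc4)[nH]c3=O)c2)cc(OC)c1OC` is compound 1 with hydrogen in place of chloro on an aromatic carbon, the 4-chlorophenyl becoming phenyl. Going by the values given here, no measured pair shows this change alone. The author expects a step in this assay of a 1.2-fold lower number from compound 1 to compound 3 (0.07 log units; within the scatter), none beyond the scatter. Compound 3 is therefore estimated at 5500 nM in this assay, between 2500 nM and 12000 nM.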

Compound 3, concentration for 50% growth inhibition: 3020 nM
Estimate against measurement, compound 3: 1.8-fold (0.26 log units) above, within the range that was stated.
By their numbers in this assay, from the lowest: compounds 3, 2 and 1 (each within the scatter of the next, the first and the last beyond it).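

For the compounds shown here, compound 3 gives the first direct reading of this change on the 4-chlorophenyl: in this assay, hydrogen in place of chloro brings a 2.1-fold lower number from compound 1 to compound 3 (0.33 log units; beyond the scatter), a modest step. In this pair, the chloro on that aromatic carbon is therefore not needed for inhibition of growth, and its loss gives a somewhat stronger result. Nothing available explains the step. From the compounds shown here alone, it remains open how fluoro, a methyl group or an amine on that carbon would compare with chloro and hydrogen. Going by these compounds, whether the step would recur on the core of compound 2 also remains open.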